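The compounds below may be only part of what the source reports. "The series", "measured", "known", "first", "only" and "open" are said of these compounds alone.

Compound 1 `Cc1cc(C)cc(-n2nncc2CN2C(=O)C3(C(C#N)=C(N)Oc4c(N)cc5nc6ccccc6nc5c43)c3ccccc32)c1`: in a functional assay on A549 cells (Homo sapiens) for antiproliferative activity, read by MTT assay, with a stated time of 48 h (on this read-out higher numbers stand for weaker inhibition and lower numbers for stronger inhibition), compound 1 gives 31200 nM.
Compound 2 `N#CC1=C(N)Oc2c(N)cc3nc4ccccc4nc3c2C12C(=O)N(Cc1cnnn1-c1ccc(F)c(Cl)c1)c1ccccc12`: in this assay compound 2 gives 43400 nM.

Compound 2 carries the higher of these two numbers, but the only step shown, a 1.4-fold higher number from compound 1 to compound 2 (0.14 log units; within the scatter), lies within the scatter, so the two compounds cannot be told apart. Compound 3 `N#CC1=C(N)Oc2c(N)cc3nc4ccccc4nc3c2C12C(=O)N(Cc1cnnn1-c1c(Cl)cc(Cl)cc1Cl)c1ccccc12` is the next change on the same aromatic nitrogen: 2,4,6-trichlorophenyl in place of 3-chloro-4-fluorophenyl on an aromatic nitrogen. That earlier exchange of one phenyl ring for another at this position left the number essentially where it was, and the exchange to compound 3 is of the same kind. No shift beyond the scatter is therefore expected, a 1.1-fold lower number from compound 2 to compound 3 (0.04 log units; within the scatter). For compound 3 the estimate is 40000 nM, with a range from 15000 nM to 110000 nM.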

Compound 3, half-maximal inhibitory concentration: > 50000 nM
Compound 3: only a limit was reported; the forecaster's own chance of this, stated with the estimate: 15%; middle value at least 1.2-fold (0.09 log units) from the limit.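

In this assay compound 3 gives only a limit, not a number: the limit of > 50000 nM in this assay, at which 1 of the 3 values shown sits. Its steps, an at least 1.1-fold higher number from compound 2 to compound 3 (0.06 log units; that floor lies within the scatter) and an at least 1.6-fold higher number from compound 1 to compound 3 (0.20 log units; that floor lies within the scatter), have floors within the scatter, so neither shows a real change. Still, 2,4,6-trichlorophenyl on this aromatic nitrogen does not bring the number down, and how far it rises cannot be read. Going by these compounds, whether a phenyl ring carrying an amine or a carboxylic acid would give a lower number stays open. So does the effect of a short alkyl chain in place of the ring.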